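The compounds below may be only part of what the source reports. "The series", "measured", "known", "first", "only" and "open" are said of these compounds alone.

Of the compounds shown here, three sharing one core have been measured in a physicochemical assay for lipophilicity, read by HPLC, at pH 7.5; on this read-out lower numbers stand for lower lipophilicity and higher numbers for higher lipophilicity. Compound 1 `CC[C@@H](Nc1c(C#N)c(-c2ccc(-c3cccc(OC)c3)cc2)nc2cnccc12)C(N)=O` gives 2.7 in this assay, compound 2 `CC[C@@H](Nc1c(C#N)c(-c2ccc(-c3ccccc3NC)cc2)nc2cnccc12)C(N)=O` gives 2.5, and compound 3 `CC[C@@H](Nc1c(C#N)c(-c2ccc(-c3ccccc3Cl)cc2)nc2cnccc12)C(N)=O` gives 2.9, the highest of the three numbers; the step of a number 0.40 log units higher from compound 2 to compound 3 (beyond the scatter) is beyond the scatter, whereas the step of a number 0.20 log units higher from compound 1 to compound 3 (within the scatter) is within it. Compound 4 `CC[C@@H](Nc1c(C#N)c(-c2ccc(-c3ccc(OC)cc3)cc2)nc2cnccc12)C(N)=O` is not yet measured. It differs from compound 3 as follows: 4-methoxyphenyl in place of 2-chlorophenyl on an aromatic carbon. Among the measured compounds shown here, the only measured step that bears on this change is a number 0.20 log units higher from compound 1 to compound 3 (within the scatter), which ran the opposite way and stayed within the scatter. Reversing it, the expected step is a number 0.20 log units lower from compound 3 to compound 4 (within the scatter), so compound 4 is estimated at 2.7, with a range from 2.4 to 3.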

Compound 4, distribution coefficient: 2.7
Estimate against measurement, compound 4: no gap at the digits printed, and the stated range covers the measured number.
By their numbers in this assay, from the lowest: compounds 2, 1, 4 and 3 (each within the scatter of the next, the first and the last beyond it).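

In this assay, 4-methoxyphenyl in place of 3-methoxyphenyl gives no change at the digits printed from compound 1 to compound 4 (within the scatter) and so opens no gap between these two methoxyphenyl groups. Against the other two groups, 4-methoxyphenyl gives a number 0.20 log units lower from compound 3 to compound 4 (within the scatter) and a number 0.20 log units higher from compound 2 to compound 4 (within the scatter) and thus places compound 4 within the scatter of both compound 2 and compound 3, although those two lie beyond the scatter of each other. No evidence is available to explain these small steps. All four groups here are substituted phenyl rings. On these data alone, how a carboxylic acid or a longer amine chain on that ring would read remains open.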